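This account rests on a few compounds, and the source may have more. Where it says the series, first, only, none or still open, it means among the compounds named here.

Measured so far in a functional assay on HCT-15 cells (Homo sapiens) for antiproliferative activity; a lower number here means a stronger inhibitor, a higher number a weaker inhibitor: compound 1 `COc1ccc(S(=O)(=O)Oc2ccccc2NC(=O)c2ccc(F)cc2)cc1` gives 89 nM. Compound 2 `COc1ccc(S(=O)(=O)Oc2ccccc2NC(=O)c2ccc(N(C)C)cc2)cc1` gives only a limit of the assay, > 10000 nM. Compound 3 `COc1ccc(S(=O)(=O)Oc2ccccc2NC(=O)c2ccccn2)cc1` gives 110 nM.

Compound 3 sits within the scatter of compound 1, the step being a 1.2-fold higher number from compound 1 to compound 3 (0.09 log units; within the scatter); against compound 2 it stands far apart, an at least 90-fold lower number from compound 2 to compound 3 (1.95 log units; beyond the scatter), compound 2 resting at the limit of > 10000 nM in this assay, at which 1 of the 3 values shown sits.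

Compound 4 `COc1ccc(S(=O)(=O)Oc2ccccc2NC(=O)Nc2ccccc2)cc1` is not yet measured. The change from compound 3 is anilino in place of pyridin-2-yl on a carbonyl carbon. Going by the values given here, two measured steps touch the same carbonyl carbon: the small one a 1.2-fold higher number from compound 1 to compound 3 (0.09 log units; within the scatter) and the large one an at least 90-fold lower number from compound 2 to compound 3 (1.95 log units; beyond the scatter); neither introduces an anilino group, so no direct precedent exists. He expects a modest step, a 1.8-fold higher number from compound 3 to compound 4 (0.26 log units; within the scatter), within or near the scatter. Compound 4 is estimated at 200 nM, between 50 nM and 1000 nM.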

Compound 4, half-maximal inhibitory concentration: > 10000 nM
Compound 4: only a limit was reported; the forecaster's own chance of this, stated with the estimate: 10%; middle value at least 50-fold (1.69 log units) away from the limit.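

In this assay compound 4 gives only a limit, which it shares with compound 2: the limit of > 10000 nM in this assay, at which 2 of the 4 values shown sit. With anilino on the carbonyl carbon the data show an at least 90-fold higher number from compound 3 to compound 4 (1.95 log units; beyond the scatter) and an at least 110-fold higher number from compound 1 to compound 4 (2.05 log units; beyond the scatter), so this place, where pyridin-2-yl and 4-fluorophenyl lie within the scatter of each other, does not accept every aromatic group. The step between compound 2 and compound 4 cannot be read, as both are limits.

Left open is whether the loss belongs to the nitrogen of the anilino group or to its unsubstituted ring. A plain phenyl or a 4-fluoroanilino group on the carbonyl carbon would separate the two.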